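A few compounds are considered here, and "the series" means these few. Any claim that something is new, unique, unknown or untested is made for them only; others in the source may bear on it.

For the measured compounds named here, of the three compounds measured so far, compound 1 `COc1ccc2c(c1)CN(C(=O)c1cc(S(C)(=O)=O)ccc1O[C@@H](C)C(F)(F)F)C2` gives the lowest number in an assay on CHO cells for inhibition of sodium- and chloride-dependent glycine transporter 1 (Homo sapiens), read by scintillation counting (a higher number here means that more compound is needed for the effect, a lower number that less compound is needed), at 180 nM. Compound 3 `C[C@H](Oc1ccc(S(C)(=O)=O)cc1C(=O)N1Cc2cccc(C#N)c2C1)C(F)(F)F` gives 770 nM in this assay, and compound 2 `Cc1cccc2c1CN(C(=O)c1cc(S(C)(=O)=O)ccc1O[C@@H](C)C(F)(F)F)C2` gives 3360 nM. Compound 4 `C[C@H](Oc1ccc(S(C)(=O)=O)cc1C(=O)N1Cc2ccc(C3CCCCO3)cc2C1)C(F)(F)F` has not yet been measured; it differs from compound 1 by oxan-2-yl in place of methoxy on an aromatic carbon. Going by the values given here, no measured step touches this particular change. Among the compounds with values here, the only recorded step, a 4.4-fold lower number from compound 2 to compound 3 (0.64 log units; beyond the scatter), exchanges one substituent for another on the same ring system and shows that a substituent change there can move the number by a modest amount. The values of compound 1 and compound 3 show that the compound bearing methoxy sits below the one bearing nitrile. Within the data shown here, the oxan-2-yl group that enters is larger than the methoxy that leaves, and no measured compound carries a ring of that kind, so the direction is uncertain. Compound 4 is expected to give 400 nM in this assay, within a range of 100 nM to 2000 nM. The step this estimate implies, a 2.2-fold higher number from compound 1 to compound 4 (0.35 log units; beyond the scatter), is expected to be modest, a somewhat higher number.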

Compound 4, half-maximal effective concentration: 205 nM
Compound 4: the middle estimate sits 2.0-fold (0.29 log units) above what was measured; low and high end bracket the measured number.
By their numbers in this assay, from the lowest: compounds 1 and 4 (each within the scatter of the next); then compound 3; then compound 2.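

Placing oxan-2-yl on this aromatic carbon in place of methoxy gives a 1.1-fold higher number from compound 1 to compound 4 (0.06 log units; within the scatter) in this assay, so the two compounds cannot be told apart there. For the compounds shown here, the earlier step showed only that a substituent exchange on this ring system can shift the number, whereas this pair shows that a larger group carrying a six-membered non-aromatic ring with 1 hetero atom can take the place of a group with no ring and stay within the scatter. Nothing in the data accounts for this result.

Going by these compounds, whether a carboxylic acid, a primary amine or a longer chain such as butoxy would behave in the same way at this carbon remains open. On these data alone, it is also open whether the same exchange would give a similar result with a group other than methylsulfonyl on the other ring.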